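This account rests on a few compounds, and the source may have more. Where it says the series, first, only, none or still open, it means among the compounds named here.

Compound 1 `N#CC1=C(N)Oc2c(c3nc4ccccc4nc3c3ccccc23)C12C(=O)N(Cc1cnnn1-c1ccccc1Cl)c1ccccc12`: in a functional assay on MCF7 cells (Homo sapiens) for antiproliferative activity, read by MTT assay, with a stated time of 48 h (on this read-out higher numbers stand for weaker inhibition and lower numbers for stronger inhibition), compound 1 gives only the limit > 50000 nM.
Compound 2 `N#CC1=C(N)Oc2c(c3nc4ccccc4nc3c3ccccc23)C12C(=O)N(Cc1cnnn1-c1ccccc1Br)c1ccccc12`: in this assay compound 2 gives only the limit > 50000 nM.
Compound 3 `N#CC1=C(N)Oc2c(c3nc4ccccc4nc3c3ccccc23)C12C(=O)N(Cc1cnnn1-c1ccc(N)cc1)c1ccccc12`: in this assay compound 3 gives only the limit > 50000 nM.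

Compound 1 thus stands at a limit of this assay and not at a number, and the same holds for the two compounds made from it. The step that the two limits leave unreadable from compound 1 to compound 2 and the step that the two limits leave unreadable from compound 1 to compound 3 cannot be sized, because the limit of > 50000 nM in this assay, at which 3 of the 3 values shown sit, is all that was recorded for every one of them; nothing in this set shows that any exchange of the aryl group on the ring nitrogen moves the read-out into the measurable range.

Compound 4 `Cc1cc(C)cc(-n2nncc2CN2C(=O)C3(C(C#N)=C(N)Oc4c3c3nc5ccccc5nc3c3ccccc43)c3ccccc32)c1` differs from compound 1 by 3,5-dimethylphenyl in place of 2-chlorophenyl on an aromatic nitrogen. For the measured compounds named here, the two measured steps that bear on it, from compound 1 to compound 2 and from compound 1 to compound 3, both leave the value at the limit, so there is no sized step to build on and no direction can be read. The expectation for compound 4 is therefore that it remains at the limit as well, with a step that the limit leaves unreadable from compound 1 to compound 4 that cannot be told from none. Compound 4 is estimated at 60000 nM, with a range from 20000 nM to 200000 nM, most probably reported again as a limit only.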

Compound 4, half-maximal inhibitory concentration: > 50000 nM
Compound 4: only a limit was reported (the forecaster's own chance of this, stated with the estimate: 85%); the middle value does not contradict the limit.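

The steps from compound 1, compound 2 and compound 3 to compound 4 cannot be read in this assay, because all four compounds stand at a limit and not at a number: the limit of > 50000 nM in this assay, at which 4 of the 4 values shown sit.

The compounds shown leave open whether any aryl group on the aromatic nitrogen of the shared core gives a measurable value.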